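This account rests on a few compounds, and the source may have more. Where it says the series, first, only, none or still open, it means among the compounds named here.

Compound 1 `CCC(CC)O[C@@H]1C=C(C(=O)O)C[C@H](NCc2ccc(Oc3ccccc3)cc2)[C@H]1NC(C)=O` carries a phenoxy group. In an ADME assay on cells (Fibroblast, Gallus gallus) for cytotoxicity, read by CCK-8 assay, with a stated time of 48 h (a lower number here means that less compound is tolerated, a higher number that more compound is tolerated), compound 1 reached only the limit of the assay, reported as > 200000 nM, so no exact number is known for it. Compound 2 `CCC(CC)O[C@@H]1C=C(C(=O)O)C[C@H](NCc2cccc(SC3CCCC3)c2)[C@H]1NC(C)=O` likewise gave only a limit in this assay, > 200000 nM. Both values therefore sit at the limit of > 200000 nM in this assay, at which 2 of the 2 values shown sit. Compound 3 `CCC(CC)O[C@@H]1C=C(C(=O)O)C[C@H](NCc2ccc(S(=O)(=O)c3ccccc3)cc2)[C@H]1NC(C)=O` differs from compound 1 by phenylsulfonyl in place of phenoxy on an aromatic carbon. For the measured compounds named here, no measured step links the two, so the change is expected to stay within the usual scatter, a step that the limit leaves unreadable from compound 1 to compound 3. For compound 3 the half-maximal cytotoxic concentration in this assay is estimated at 250000 nM, within 120000 nM to 500000 nM, and most likely again only a limit.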

Compound 3, half-maximal cytotoxic concentration: > 200000 nM
Compound 3: a limit, no number; the forecaster's own chance of this, stated with the estimate: 85%; the middle value is on the limit's open side.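

For the compounds shown here, compound 3 gives > 200000 nM, again a limit and not a number, so no step from compound 1 can be read. The compounds shown leave open whether phenoxy and phenylsulfonyl differ at all in this assay.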